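From 2-carboxypiperidin-1-yl to (2-hydroxyethyl)amino on compound 2

A few compounds are considered here, and "the series" means these few. Any claim that something is new, unique, unknown or untested is made for them only; others in the source may bear on it.

Within the data shown here, in an ADME assay on HEK293 cells (Homo sapiens) for cytotoxicity, read by CCK-8 assay, with a stated time of 48 h (a higher number here means a weaker inhibitor, a lower number a stronger inhibitor), compound 2 `COc1ccc(/C=C\c2cc(OC)c(OC)c(OC)c2)cc1OCc1ccc(CN2CCCC[C@@H]2C(=O)O)cc1` gives 42000 nM, the only actual number. Compound 1 `COc1ccc(/C=C\c2cc(OC)c(OC)c(OC)c2)cc1OCc1ccc(CN2CCCC[C@H]2C(=O)O)cc1` stands at a limit of this assay, > 50000 nM. Compound 3 `COc1ccc(/C=C\c2cc(OC)c(OC)c(OC)c2)cc1OCc1ccc(CN2CCCCC2C(=O)O)cc1` stands at a limit too, > 50000 nM. Compound 4 `COc1ccc(/C=C\c2cc(OC)c(OC)c(OC)c2)cc1OCc1ccc(CNCCO)cc1` differs from compound 2 in one place: (2-hydroxyethyl)amino in place of 2-carboxypiperidin-1-yl on a saturated chain carbon bound to an aromatic carbon. The measured steps, an at least 1.1-fold lower number from compound 1 to compound 2 (0.07 log units; that floor lies within the scatter) and an at least 1.1-fold higher number from compound 2 to compound 3 (0.07 log units; that floor lies within the scatter), concern configuration only, show nothing beyond the scatter and set no size for this change. With compound 2 at 42000 nM, little room remains upward, so a lower number is expected, though its size is poorly defined. The expected step is a 3.5-fold lower number from compound 2 to compound 4 (0.54 log units; beyond the scatter). For compound 4 the estimate is 12000 nM, with an expected range of 1500 nM to 50000 nM.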

Compound 4, half-maximal inhibitory concentration: > 50000 nM
Compound 4: a limit, no number; the forecaster's own chance of this, stated with the estimate: 20%; at least 4.1-fold (0.61 log units) between middle value and limit.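

In this assay compound 4 gives > 50000 nM, which is a limit and not a number. Among these compounds, the change of group on a saturated chain carbon bound to an aromatic carbon gives an at least 1.1-fold higher number from compound 2 to compound 4 (0.07 log units; that floor lies within the scatter), so this position now shows no step beyond the scatter for a change of group either, where the earlier compounds differed in configuration only. The steps to compound 4 from compound 1 and compound 3 cannot be read, as both ends are limits.

Going by these compounds, the true size of the step to compound 4 stays open. Also open, on these data alone, is how a morpholine, or a longer chain ending in a carboxylic acid, would read at this place in this assay.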